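Swapping fluoro for chloro on a bis-furan amidine

The source may hold more compounds than are shown below. What is called first, only, known or untested is meant among the compounds shown, and "the series" means these compounds.

Two heteroaryl amidines have so far been measured in a functional assay on RPMI-8226 cells (Homo sapiens) for inhibition, read by sulforhodamine B assay, with a stated time of 48 h; a higher number here means a weaker inhibitor of growth, a lower number a stronger inhibitor of growth. Compound 1 `N=C(N)c1ccc(-c2ccc(-c3cncc4ccccc34)s2)s1` gives 1780 nM. Compound 2 `N=C(N)c1ccc(-c2ccc(-c3ccc(F)cc3)o2)o1` gives 2480 nM, the higher of the two numbers, though its gap to compound 1 lies within the usual scatter, so the two values cannot be told apart. Compound 3 `N=C(N)c1ccc(-c2ccc(-c3ccc(Cl)cc3)o2)o1` has not yet been measured. It differs from compound 2 in one place, (chloro in place of fluoro on an aromatic carbon), which puts chloro in place of fluoro on an aromatic carbon. Among the measured compounds shown here, no measured pair here shows such an exchange, so any expectation rests on the change itself, and on that basis only a small step, if any, is expected, with a slight lean towards a lower number. The estimate implies a step of a 1.4-fold lower number from compound 2 to compound 3 (0.14 log units; within the scatter). Compound 3 is therefore estimated at 1800 nM, with a range from 700 nM to 4500 nM.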

Compound 3, concentration for 50% growth inhibition: 2120 nM
Compound 3: the middle estimate sits 1.2-fold (0.07 log units) below what was measured; the measured number falls inside the stated range.
By their numbers in this assay, from the lowest: compounds 1, 3 and 2 (each within the scatter of the next).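

In this assay, placing chloro in place of fluoro on an aromatic carbon, para to a large group, gives a 1.2-fold lower number from compound 2 to compound 3 (0.07 log units; within the scatter), so compound 2 and compound 3 cannot be told apart. Among the compounds shown here, this is the first measured pair to carry this exchange, and it shows that, at this position on this core, the read-out does not separate the two halogens. No measurement is available that bears on the reason for this result.

The compounds shown leave open what a group other than a halogen, such as an amine, a methoxy group or a carboxylic acid, would do at this position. For the compounds shown here, they also leave open whether the same exchange would give a similar result on another core, as only this single pair carries it.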